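The source may report more compounds than this note shows. Statements on the series, on what has been measured and on what is new or still open speak of the compounds shown alone.

Working notes on the series. Compound 1 `CC(C)=CCCC(=O)[C@]1(/C=C/C(C)C)C[C@H](CC=C(C)C)C(C)(C)[C@@H](C(=O)c2ccccc2)C1=O`, compound 2 `COC(=O)[C@@]1(CC=C(C)C)C[C@H](CC=C(C)C)C(C)(C)[C@H](C(=O)C(C)C)C1=O` and compound 3 `CC(C)=CC[C@@H]1C[C@H](CC=C(C)C)C(C)(C)[C@H](C(=O)C(C)C)C1=O` have each been run in a functional assay on A549 cells (Homo sapiens) for cytotoxicity, read by CellTiter-Glo, with a stated time of 5 days; a lower number here means a stronger inhibitor, a higher number a weaker inhibitor. For compound 1 the read-out is only a limit, > 10000 nM. For compound 2 the read-out is likewise a limit, > 10000 nM. Compound 3 also returns a limit, > 10000 nM, so on the numbers shown compound 3 sits at the limit of > 10000 nM in this assay, at which 3 of the 3 values shown sit. Compound 4 `CC(C)=CC[C@@H]1C[C@H](CC=C(C)C)C(C)(C)[C@@H](C(=O)C(C)C)C1=O` is next; it differs from compound 3 as follows: the two compounds have the same atoms and bonds and differ only in configuration as drawn: 1 of 3 stereo elements differ; a stereocentre at a saturated ring carbon is drawn R in compound 3 and S in compound 4. Going by the values given here, no step between measured compounds is available, so in this assay no change beyond the scatter is expected, most likely a limit again. The step that the limit leaves unreadable from compound 3 to compound 4 is the expected outcome. Compound 4 is estimated at 15000 nM, within 5000 nM to 50000 nM.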

Compound 4, half-maximal inhibitory concentration: > 10000 nM
Compound 4 ended at the assay's limit; the forecaster's own chance of this, stated with the estimate: 80%; the middle value lies beyond the limit too.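

Going by these compounds alone, compound 3 and compound 4 both stand at a limit, and no step between them can be read. The compounds shown leave open whether the configuration at that saturated ring carbon changes potency, and where any of them lies beyond the limit.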